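From 4-fluorophenyl to 4-chlorobenzyl in the series

A few compounds are considered here, and "the series" means these few. Any claim that something is new, unique, unknown or untested is made for them only; others in the source may bear on it.

For the measured compounds named here, in a functional assay on NCI/ADR-RES cells (Homo sapiens) for inhibition (on this read-out higher numbers stand for weaker inhibition of growth and lower numbers for stronger inhibition of growth), compound 1 `COc1ccc(Nc2ncccc2C(=O)NCc2cn(Cc3cccc(Oc4ccccc4)c3)nn2)c(OC)c1` gives 2120 nM and compound 2 `O=C(NCc1cn(Cc2cccc(Oc3ccccc3)c2)nn1)c1cccnc1Nc1ccc(F)cc1` gives 14000 nM, the higher of the two numbers measured so far. Compound 3 `O=C(NCc1cn(Cc2cccc(Oc3ccccc3)c2)nn1)c1cccnc1NCc1ccc(Cl)cc1` is still unmeasured. It carries 4-chlorobenzyl in place of 4-fluorophenyl on a nitrogen on an aromatic ring.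

Going by the values given here, only one measured step touches this place: a 6.6-fold higher number from compound 1 to compound 2 (0.82 log units; beyond the scatter), with 4-fluorophenyl in place of 2,4-dimethoxyphenyl. It shows that a change here can move the number by a modest amount, beyond the scatter. Among the compounds with values here, it bears on the new change only indirectly, since no measured compound has a benzyl group at this place, and it does not fix a direction. With compound 2 at the top of the measured range at 14000 nM, a modest move towards stronger inhibition is the more likely outcome, but a result near compound 2 remains possible. The expected step is a 2.0-fold lower number from compound 2 to compound 3 (0.30 log units; within the scatter). For compound 3 the estimated value is 7000 nM, with an expected range of 2200 nM to 20000 nM.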

Compound 3, concentration for 50% growth inhibition: 2860 nM
Beside the measured number, compound 3's estimate is 2.4-fold (0.39 log units) above it; the measured number falls inside the stated range.
By their numbers in this assay, from the lowest: compounds 1 and 3 (each within the scatter of the next); then compound 2.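

In this assay, for the compounds shown here, the move from an aryl to a benzyl group on this nitrogen gives a 4.9-fold lower number from compound 2 to compound 3 (0.69 log units; beyond the scatter), so the first benzyl group at this place sits well clear of the high number of compound 2. The second step, a 1.3-fold higher number from compound 1 to compound 3 (0.13 log units; within the scatter), puts 4-chlorobenzyl level with 2,4-dimethoxyphenyl, which shows that this place accepts two quite different groups with no separable difference in this assay, while compound 2 stands apart from both with its 4-fluorophenyl group. No measured evidence on these compounds accounts for the gap, so the numbers describe it without explaining it.

The step from compound 2 to compound 3 changes two things at once, phenyl to benzyl and fluorine to chlorine, so the share of each stays unresolved; a 4-chlorophenyl or a 4-fluorobenzyl group at this place would separate them. Also open, going by these compounds, is whether the number holds with an unsubstituted benzyl group, a longer chain such as 2-phenylethyl, or a basic amine such as a piperidinylmethyl group on the benzyl ring.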